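The source may hold more compounds than are shown below. What is called first, only, known or untested is meant among the compounds shown, and "the series" means these compounds.

Of the compounds shown here, three built on one shared core have been tested in a functional assay on BJAB cells (Homo sapiens) for antiproliferative activity, with a stated time of 4 days; on this read-out higher numbers stand for an effect only at larger amounts of compound and lower numbers for an effect already at smaller amounts. Compound 1 `Cc1nn(-c2nc(-c3ccc(Cl)c(Cl)c3)c(SC(C)C)s2)c(C(=O)O)c1-c1cccc(Cl)c1C` gives 5100 nM in this assay, and compound 2 `Cc1nn(-c2nc(-c3ccc(Cl)c(Cl)c3)c(SC(C)C)s2)c(C(=O)O)c1-c1ccncc1` gives 5900 nM. Compound 3 `Cc1nn(-c2nc(-c3ccc(Cl)c(Cl)c3)c(SC(C)C)s2)c(C(=O)O)c1-c1ccccc1Cl` gives 13100 nM, the highest of the three numbers. The two steps that lead up to it are a 2.2-fold higher number from compound 2 to compound 3 (0.35 log units; beyond the scatter) and a 2.6-fold higher number from compound 1 to compound 3 (0.41 log units; beyond the scatter), so compound 3 stands alone at the high end, while the two compounds below it differ from each other by only a 1.2-fold higher number from compound 1 to compound 2 (0.06 log units; within the scatter).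

Compound 4 `Cc1nn(-c2nc(-c3ccc(Cl)c(Cl)c3)c(SC(C)C)s2)c(C(=O)O)c1-c1cccc(Cl)c1` has not yet been measured in this assay. It differs from compound 3 in one place: 3-chlorophenyl in place of 2-chlorophenyl on an aromatic carbon. Two of the steps seen so far bear on this change, the two that end at compound 3; each of them swaps the 2-chlorophenyl for another ring. Both were modest, a 2.6-fold higher number from compound 1 to compound 3 (0.41 log units; beyond the scatter) and a 2.2-fold higher number from compound 2 to compound 3 (0.35 log units; beyond the scatter), and both point the same way: leaving the 2-chlorophenyl gave a lower number. Compound 1, whose 3-chloro-2-methylphenyl is the ring closest in name to the entering 3-chlorophenyl, lies at 5100 nM. For compound 4 a modest step down is therefore expected, a 2.0-fold lower number from compound 3 to compound 4 (0.30 log units; within the scatter). The estimated value for compound 4 in this assay is 6500 nM, with a likely range from 3000 nM to 14000 nM.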

Compound 4, half-maximal effective concentration: 13600 nM
Compound 4: middle estimate off by 2.1-fold (0.32 log units), on the low side; the measured number falls inside the stated range.
By their numbers in this assay, from the lowest: compounds 1 and 2 (each within the scatter of the next); then compounds 3 and 4 (each within the scatter of the next).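

In this assay, moving the chlorine from the 2-chlorophenyl to the 3-chlorophenyl, with the same atoms joined differently, gives two compounds that cannot be told apart: a 1.0-fold higher number from compound 3 to compound 4 (0.02 log units; within the scatter). Within the data shown here, the clear differences on this ring lie elsewhere, since the single swap of hydrogen for methyl gives a 2.7-fold higher number from compound 1 to compound 4 (0.43 log units; beyond the scatter), and replacing pyridin-4-yl with 3-chlorophenyl gives a 2.3-fold higher number from compound 2 to compound 4 (0.36 log units; beyond the scatter), a step much like the one printed for the 2-chlorophenyl. So among these four compounds, the placement of the chlorine makes no readable difference, whereas the methyl of compound 1 does, and no measurement is available that explains either observation.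

As far as these compounds go, it remains open whether a 4-chlorophenyl or a plain phenyl would fall with compound 3 and compound 4 or with compound 1 and compound 2, and whether a methyl helps only when chlorine sits on the same ring, as a 2-methylphenyl could show. From the compounds shown here alone, the carboxylic acid is the same in all four compounds, so what an amide or a methyl ester would do at that place also stays open.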